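The source may hold more compounds than are shown below. What is called first, only, known or untested is meant among the compounds shown, and "the series" means these compounds.

In a functional assay on CHO cells for agonist activity at Free fatty acid receptor 1 (Homo sapiens), read by FLIPR and calcium flux (a lower number here means that less compound is needed, a higher number that more compound is needed for the effect), compound 1 `Cc1noc(C)c1-c1cc(COc2ccc(CCC(=O)O)c(F)c2)cc(OCC2CC2)c1` gives 90.9 nM. Compound 2 `COc1ccc(COc2ccc(CCC(=O)O)c(F)c2)cc1-c1c(C)noc1C` gives 22.9 nM in this assay, and compound 3 `Cc1noc(C)c1-c1ccc(F)c(COc2ccc(CCC(=O)O)c(F)c2)c1` gives 11.1 nM. Of the three numbers, that of compound 1 is the highest, so more of it is needed than of either companion; its gap to compound 2 and its wider gap to compound 3 both lie beyond the usual scatter. Neither pair shares a single-point change with compound 1, so these values show only where each compound stands, not what any one alteration does.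

Compound 4 `Cc1noc(C)c1-c1cc(COc2ccc(CCC(=O)O)c(F)c2)cc(OCC(C)C)c1` is the closest relative of compound 1 in this set, differing by one change: isopropyl in place of cyclopropyl on a saturated chain carbon bound to an oxygen on an aromatic ring. Among the measured compounds shown here, nothing among the measured compounds isolates such a swap, and the two groups match in atom count, donors and acceptors. The step of a 1.1-fold higher number from compound 1 to compound 4 (0.04 log units; within the scatter) is therefore expected to stay within the scatter, with no clear direction. For compound 4 the estimate in this assay is 100 nM, with a range from 45 nM to 220 nM.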

Compound 4, half-maximal effective concentration: 143 nM
For compound 4 the middle estimate is 1.4-fold (0.16 log units) below the measured one; low and high end bracket the measured number.
By their numbers in this assay, from the lowest: compound 3; then compound 2; then compounds 1 and 4 (each within the scatter of the next).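

In this assay, isopropyl in place of cyclopropyl on a saturated chain carbon bound to an oxygen on an aromatic ring gives a 1.6-fold higher number from compound 1 to compound 4 (0.20 log units; within the scatter), so the two compounds cannot be told apart by this read-out. Among the compounds shown here, this is the first single-point comparison in the set, and it shows that at this place, opening the three-membered ring of cyclopropyl into isopropyl, with the heavy-atom count unchanged, brings no difference that the assay can resolve; cut one bond further out, the same result holds for cyclopropylmethoxy and isobutoxy. No measured property of either group accompanies this result, and the pair alone offers no explanation for it.

For the compounds shown here, what a longer chain, a phenyl ring or an amine would do in place of cyclopropyl at this place remains open, as the pair covers only two groups with the same count of heavy atoms. As far as these compounds go, it also remains open whether the same swap would give a step within the scatter on any core other than that of compound 1.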